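A few compounds are considered here, and "the series" means these few. Any claim that something is new, unique, unknown or untested is made for them only; others in the source may bear on it.

Measured in an ADME assay on the whole organism (plasma, strain Beagle) for pharmacokinetics, with Canis familiaris (Canis lupus familiaris) as the target, read by LC-MS, with a stated time of 8 h, at a dose of 10 mg/kg by the intraduodenal route; on this read-out higher numbers stand for higher exposure at the dose given and lower numbers for lower exposure:
compound 1 `CCOC(=O)C1=C(S[C@@H]2CN[C@H](C(=O)Nc3cccc(C(=O)OCC)c3)C2)[C@H](C)[C@@H]2[C@@H]([C@@H](C)OC(C)=O)C(=O)N12`: < 57.4 ng.h/mL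
compound 2 `C[C@@H](O)[C@H]1C(=O)N2C3=C(S[C@@H]4CN[C@@H](C4)C(=O)Nc4cccc(c4)C(=O)OCCCOC3=O)[C@H](C)[C@H]12`: 51.6 ng.h/mL
compound 3 `C[C@@H](O)[C@H]1C(=O)N2C3=C(S[C@@H]4CN[C@@H](C4)C(=O)Nc4cccc(c4)C(=O)OCc4oc(=O)oc4COC3=O)[C@H](C)[C@H]12`: "below limit of detection" (no number reported)

The entry for compound 1 is a limit of the assay, not a number; it stands at the limit of < 57.4 ng.h/mL in this assay, at which 1 of the 3 values shown sits. Compound 2 gives a number in this assay. Compound 3 gives no number at all. Within the data shown here, no step between measured compounds is available, so no measured size of step can be read here.

Compound 4 `CCOC(=O)C1=C(S[C@@H]2CN[C@H](C(=O)Nc3cccc(C(=O)OCC)c3)C2)[C@H](C)[C@@H]2[C@@H]([C@@H](C)OC(=O)CC)C(=O)N12` differs from compound 1 by methyl in place of hydrogen on a saturated chain carbon bound to a carbonyl carbon. The expected step is a step that the limit leaves unreadable from compound 1 to compound 4, not beyond the scatter, and a limit rather than a number is as likely as not. Compound 4 is estimated at 45 ng.h/mL, within 10 ng.h/mL to 180 ng.h/mL.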

Compound 4, area under the concentration-time curve: "below limit of detection" (no number reported)
For compound 4 the study gives words and no number; the estimate stays without a comparison.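

No step can be read from compound 1 to compound 4: compound 4 has words and no number, and compound 1 has only a limit. The compounds shown leave open whether going from acetoxy to propanoyloxy shifts exposure at all.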